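Fluoro-to-nitro swap on the aryl ring: estimate for compound 4

A few compounds are considered here, and "the series" means these few. Any claim that something is new, unique, unknown or untested is made for them only; others in the source may bear on it.

Among the measured compounds shown here, compound 1 `CC(=O)OC/C(=C\c1ccc(F)cc1)C(=O)c1ccccc1` is the first member of the set; in a functional assay on T47D cells (Homo sapiens) for inhibition, read by sulforhodamine B assay, with a stated time of 48 h (a higher number here means a weaker inhibitor of growth, a lower number a stronger inhibitor of growth), compound 1 gives 14000 nM. Compound 2 `CC(=O)OC/C(=C\c1ccccc1F)C(=O)c1ccccc1` differs from compound 1 in the way stated by 2-fluorophenyl in place of 4-fluorophenyl on a double-bonded chain carbon bound to a double-bonded chain carbon, and in this assay compound 2 gives 18000 nM; the step is a 1.3-fold higher number from compound 1 to compound 2 (0.11 log units; within the scatter). Compound 3 `CC(=O)OC/C(=C\c1ccc([N+](=O)[O-])cc1)C(=O)c1ccccc1` carries the change nitro in place of fluoro on an aromatic carbon relative to compound 1, and in this assay compound 3 gives 16000 nM; the step is a 1.1-fold higher number from compound 1 to compound 3 (0.06 log units; within the scatter). Among the three measured compounds the values of compound 1, compound 2 and compound 3 all lie within the usual scatter of one another, so no ordering among them is claimed.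

Compound 4 `CC(=O)OC/C(=C\c1ccccc1[N+](=O)[O-])C(=O)c1ccccc1` has not yet been measured. It differs from compound 2 by nitro in place of fluoro on an aromatic carbon. For the measured compounds named here, this is the same kind of change as the one from compound 1 to compound 3, with one difference in the surroundings of the place: in compound 3 the entering nitro is para to a large group, whereas in compound 4 it is ortho to a large group. Going by the values given here, the only measured example of this kind of change is the step of a 1.1-fold higher number from compound 1 to compound 3 (0.06 log units; within the scatter), which lies within the scatter.

On that basis, the step from compound 2 to compound 4 in this assay is expected to be small, about a 1.1-fold higher number from compound 2 to compound 4 (0.05 log units; within the scatter), because the measured precedent is a 1.1-fold higher number from compound 1 to compound 3 (0.06 log units; within the scatter). The expectation rests on a single pair of compounds and on the value of compound 2, 18000 nM. For compound 4 in this assay the estimated value is 20000 nM, with a range from 9000 nM to 45000 nM.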

Compound 4, concentration for 50% growth inhibition: 21000 nM
Compound 4: middle estimate off by 1.1-fold (0.02 log units), on the low side, and the stated range covers the measured number.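

In this assay the swap of fluoro for nitro on the aromatic carbon ortho to a large group gives a 1.2-fold higher number from compound 2 to compound 4 (0.07 log units; within the scatter), and the two examples of this change agree: the same change on two cores in this assay, a 1.1-fold higher number (0.06 log units; within the scatter) from compound 1 to compound 3 and a 1.2-fold higher number (0.07 log units; within the scatter) from compound 2 to compound 4, 1.0-fold (0.01 log units) apart, within the scatter of two such steps. Across the core of compound 1 and the core of compound 2, the change therefore carries over as a step that stays within the scatter, and the location of the fluoro or nitro group on the ring makes no visible difference to it in these two pairs. This does not show that fluoro and nitro are interchangeable in general, since neither step can be given a direction, the evidence is two pairs in one assay, and a change that barely moves the number on two closely related cores says nothing about its size on a different core.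

The compounds shown leave open whether any other group in that place, such as an amine, a carboxylic acid or a methoxy group, would give a step beyond the scatter in this assay. They also leave open what happens when the acetate ester is replaced by a free hydroxyl or a longer-chain ester, or when the unsubstituted benzoyl ring carries a substituent.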